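The source may hold more compounds than are shown below. What is called first, only, known or untested is meant among the compounds shown, and "the series" means these compounds.

In a functional assay on PC-3 cells (Homo sapiens) for antiproliferative activity, read by MTT assay, with a stated time of 72 h (a lower number here means a stronger inhibitor, a higher number a weaker inhibitor), three compounds that share one core have been measured. Compound 1 `C#CCCOC(=O)c1ccc(C(CC)(CC)c2ccc(C#CC(O)(CC)CC)c(C)c2)n1CC` gives > 50000 nM, which is a limit of the assay and not a number. Compound 2 `CCn1c(C(=O)On2nnc3ccccc32)ccc1C(CC)(CC)c1ccc(C#CC(O)(CC)CC)c(C)c1` gives > 50000 nM, which is also a limit. Within the data shown here, compound 3 `CCn1c(C(=O)N[C@H](C(=O)O)C(C)C)ccc1C(CC)(CC)c1ccc(C#CC(O)(CC)CC)c(C)c1` gives 5000 nM, the only actual number among the three.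

Two measured steps lead to compound 3. One is an at least 10-fold lower number from compound 1 to compound 3 (1.00 log units; beyond the scatter), and the other is an at least 10-fold lower number from compound 2 to compound 3 (1.00 log units; beyond the scatter). In both, (1-carboxy-2-methylpropyl)amino arrives on the carbonyl carbon. Their true sizes may be larger, since each starts from a limit.

The next compound, compound 4 `CCn1c(C(=O)NCCCO)ccc1C(CC)(CC)c1ccc(C#CC(O)(CC)CC)c(C)c1`, keeps the amide-type nitrogen but changes the group on it: 3-hydroxypropyl in place of 1-carboxy-2-methylpropyl on an amide-type nitrogen. In words, 3-hydroxypropyl stands in place of 1-carboxy-2-methylpropyl. Among the measured compounds shown here, no measured step makes this exact exchange, so the two steps offer only rough guidance. Compound 4 keeps the nitrogen link, which suggests that it need not fall back to the limit. However, it loses the group that compound 3 carries at 5000 nM, so a small move towards a weaker result seems more likely than a gain. The expected change is a 2.0-fold higher number from compound 3 to compound 4 (0.30 log units; within the scatter), and it remains uncertain. The estimated value for compound 4 is 10000 nM, with an expected range from 2500 nM to 40000 nM.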

Compound 4, half-maximal inhibitory concentration: > 50000 nM
Compound 4 was reported as a limit; the forecaster's own chance of this, stated with the estimate: 25%; middle value at least 5.0-fold (0.69 log units) from the limit.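

In this assay compound 4 gives > 50000 nM, which is a limit of the assay and not a number. Among these compounds, with the amide-type nitrogen kept, 3-hydroxypropyl in place of 1-carboxy-2-methylpropyl gives an at least 10-fold higher number from compound 3 to compound 4 (1.00 log units; beyond the scatter), so the nitrogen link alone is not enough to give the measured value of compound 3, a point the earlier steps could not settle since each changed the link and the group together. The steps to compound 4 from compound 1 and from compound 2 cannot be read, and compound 3 remains the only compound with an actual number: the limit of > 50000 nM in this assay, at which 3 of the 4 values shown sit.

Which part of 1-carboxy-2-methylpropyl matters stays open, since the carboxylic acid, the branched carbon chain and the defined stereocentre all leave together in this single step. A 3-carboxypropyl group, which holds the acid on an unbranched chain, and a plain 2-methylpropyl group, which keeps branching without the acid, would help to separate these parts, as would the opposite stereocentre of the group in compound 3.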